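From 2-Methylbenzyl to Cyclopentylmethyl in Aldehyde Dehydrogenase Inhibition

The source may hold more compounds than are shown below. What is called first, only, known or untested is meant among the compounds shown, and "the series" means these compounds.

In an assay on isolated protein for inhibition of aldehyde dehydrogenase 1A1 (Homo sapiens), read by spectrophotometry, tested at 10 uM (on this read-out lower numbers stand for less inhibition and higher numbers for more inhibition at the one concentration tested (going by the name of the read-out)), three compounds have been compared so far. Compound 1 `Cc1ccccc1Cn1c(CN2CCN(C(=O)C3CC3)CC2)nc2ccccc21` gives 29.1%, compound 2 `CC(C)CCn1c(OC2CCN(C(=O)c3ccco3)CC2)nc2ccccc21` gives 30.8%, and compound 3 `Cc1cccc(Cn2c(CN3CCN(C(=O)c4cccnc4)CC3)nc3ccccc32)c1` gives 24.5%. Compound 1 thus holds the second highest of the three numbers, but its gaps to compound 2 and to compound 3 both lie within the usual scatter, so the three compounds sit on one level. Compound 4 `O=C(C1CC1)N1CCN(Cc2nc3ccccc3n2CC2CCCC2)CC1` has not yet been measured in this assay. It differs from compound 1 in one place: cyclopentyl in place of 2-methylphenyl on a saturated chain carbon bound to an aromatic nitrogen. For the measured compounds named here, no measured pair in this set isolates such a change, so there is no step to lean on. The change is expected to give a number 2.1 percentage points lower from compound 1 to compound 4 (within the scatter), a step not beyond the scatter in either direction. Compound 4 is accordingly estimated at 27%, between 12% and 42%.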

Compound 4, a percentage reported as inhibition, at one concentration (the size of the read-out at that concentration, not a potency): 44.5%
Compound 4: the middle estimate sits 17.5 percentage points below what was measured; measured number above the stated range.
By their numbers in this assay, from the lowest: compounds 3, 1 and 2 (each within the scatter of the next); then compound 4.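

Cyclopentyl in place of 2-methylphenyl on a saturated chain carbon bound to an aromatic nitrogen gives a number 15.4 percentage points higher from compound 1 to compound 4 (beyond the scatter) in this assay, so this place can move the number, which the earlier compounds could not show. On the core of compound 1, an aromatic ring is not needed here. Nothing at hand accounts for the step.

The compounds shown leave open whether cyclohexyl or unsubstituted phenyl at this place would match compound 4. They also leave open whether the step carries over to any other core.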